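This account rests on a few compounds, and the source may have more. Where it says the series, first, only, none or still open, it means among the compounds named here.

Compound 3 `C#CC(=O)N1C(c2ccccc2F)SC[C@@H]1C(=O)OCC` gives 1700 nM in a functional assay on MV cells (Homo sapiens) for inhibition, read by sulforhodamine B assay; a lower number here means a stronger inhibitor, a higher number a weaker inhibitor. Compound 1 `C#CC(=O)N1C(c2cccc(F)c2)SC[C@@H]1C(=O)OCC` gives 1700 nM, so the step of no change at the digits printed from compound 1 to compound 3 (within the scatter) from one fluorophenyl to the other leaves the number where it was. Compound 2 `C#CC(=O)N1C(c2ccc(OC)cc2)SC[C@@H]1C(=O)OCC` gives 700 nM, the lowest of the three values. Compound 4 `C#CC(=O)N1C(c2ccc(F)cc2)SC[C@@H]1C(=O)OCC` differs from compound 3 in one place: 4-fluorophenyl in place of 2-fluorophenyl on a saturated ring carbon. Within the data shown here, the one measured step that bears on this change, from compound 1 to compound 3, was flat, while compound 2, which carries its 4-methoxyphenyl on the same saturated ring carbon, sits lower; no fluorine has yet been placed as in compound 4. Compound 4 is therefore expected to show a small fall, a 1.4-fold lower number from compound 3 to compound 4 (0.15 log units; within the scatter), with an estimate of 1200 nM and a range from 500 nM to 3000 nM.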

Compound 4, half-maximal inhibitory concentration: 400 nM
Compound 4: middle estimate off by 3.0-fold (0.48 log units), on the high side; measured number outside the range, below it.
By their numbers in this assay, from the lowest: compounds 4 and 2 (each within the scatter of the next); then compounds 1 and 3 (each within the scatter of the next).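

The 4-fluorophenyl group stands apart from the other two fluorophenyl groups in this assay, with a 4.3-fold lower number from compound 3 to compound 4 (0.63 log units; beyond the scatter) and a 4.3-fold lower number from compound 1 to compound 4 (0.63 log units; beyond the scatter), so the place of the fluorine does matter on this ring, although the earlier step between compound 1 and compound 3 was flat. Fluoro and methoxy on the same aromatic carbon are not told apart, with a 1.8-fold lower number from compound 2 to compound 4 (0.24 log units; within the scatter). Nothing measured here accounts for the difference among the fluorophenyl groups.

On these data alone, what remains open is whether a 4-chlorophenyl or 4-aminophenyl group would keep the number of compound 4, and whether a carboxylic acid could stand in place of the ethoxycarbonyl group.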